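Acid to primary amide on the shared core

The source may report more compounds than this note shows. Statements on the series, on what has been measured and on what is new or still open speak of the compounds shown alone.

Compound 1 `Cc1nc(-c2ccc(C(F)(F)F)cc2)sc1CNc1ccc(CCC(=O)O)cc1` is the reference of this small set. In a functional assay on CHO cells for agonist activity at Free fatty acid receptor 1 (Homo sapiens) (on this read-out lower numbers stand for an effect already at smaller amounts and higher numbers for an effect only at larger amounts of compound), compound 1 gives 67.6 nM. The second measured compound, compound 2 `CC(Cc1ccc(NCc2cccc(Oc3ccccc3)c2)cc1)C(=O)O`, carries a different aryl part on the same propanoic-acid side; in this assay compound 2 gives 100 nM. For the measured compounds named here, compound 1 thus holds one of only two numbers, and the two numbers lie within the usual scatter of each other, so no ranking between compound 1 and compound 2 can be read from them. Going by the values given here, no step between measured compounds has been followed so far.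

Compound 3 `Cc1nc(-c2ccc(C(F)(F)F)cc2)sc1CNc1ccc(CCC(N)=O)cc1` is the next compound and differs from compound 1 at the end of the side chain: amino in place of hydroxy on a carbonyl carbon. Among the compounds with values here, no measured pair in the set shows a change of this kind, so the size of the step rests on the change alone. The expectation for compound 3 in this assay is a move to a clearly higher number, beyond the scatter, estimated as an 8.9-fold higher number from compound 1 to compound 3 (0.95 log units; beyond the scatter). For compound 3 the expected value is 600 nM, with a range from 150 nM to 3000 nM.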

Compound 3, half-maximal effective concentration: 12.9 nM
Estimate against measurement, compound 3: 47-fold (1.67 log units) above; measured number below the stated range.
By their numbers in this assay, from the lowest: compound 3; then compounds 1 and 2 (each within the scatter of the next).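

In this assay the end of the side chain on the shared core proves open to change: carbamoyl in place of carboxy gives a 5.2-fold lower number from compound 1 to compound 3 (0.72 log units; beyond the scatter), a modest step that lies beyond the scatter. The earlier compounds shown here both carry a carboxy group and could not show this, whereas this one pair shows that a free carboxy at this place is not needed for a low number on this read-out. No measurement shown here bears on why amino in place of hydroxy on a carbonyl carbon lowers the number, so the step stands without an explanation.

For the compounds shown here, it remains open whether the same change would give a step of similar size on the aryl part of compound 2, as this change is seen only on the core of compound 1. Also open, as far as these compounds go, is how the number responds to other groups at the end of the side chain, such as a nitrile, a methyl ester or a substituted amide, and to a shorter or longer chain carrying the carbamoyl group.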